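Adding a (chloromethyl)carbonyl group to compound 2

This account rests on a few compounds, and the source may have more. Where it says the series, first, only, none or still open, it means among the compounds named here.

Of the compounds shown here, two have so far been measured in an ADME assay on the whole organism (thoracic aorta) with Rattus norvegicus as the target; on this read-out lower numbers stand for smaller maximal responses and higher numbers for larger maximal responses. Compound 1 `O=C(CI)Nc1ccc(CC2=NCCN2)cc1` gives 13%. Compound 2 `Nc1ccc(CC2=NCCN2)cc1` gives 9%. Among the measured compounds shown here, compound 2 thus stands at the lower of the two numbers, with compound 1 as its only neighbour, and the step of a number 4 percentage points lower from compound 1 to compound 2 (within the scatter) lies within the scatter, so the two values cannot be ranked against each other.

Compound 3 `O=C(CCl)Nc1ccc(CC2=NCCN2)cc1` is not yet measured in this assay. For the measured compounds named here, it differs from compound 2 in one place: (chloromethyl)carbonyl in place of hydrogen on a nitrogen on an aromatic ring The only measured step bearing on this change is a number 4 percentage points lower from compound 1 to compound 2 (within the scatter), which removed the related (iodomethyl)carbonyl group and moved the number by an amount within the scatter. Because the step of a number 4 percentage points lower from compound 1 to compound 2 (within the scatter) was small, the step of a number 4 percentage points higher from compound 2 to compound 3 (within the scatter) is expected to stay within the scatter as well, in no clear direction. Compound 3 is estimated at 13%, within a range from 5% to 23%.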

Compound 3, largest response reached (Emax), in percent of the reference or control that the assay uses: 32%
Compound 3: the middle estimate sits 19 percentage points below what was measured; measured number above the stated range.
By their numbers in this assay, from the lowest: compounds 2 and 1 (each within the scatter of the next); then compound 3.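

In this assay, the nitrogen on an aromatic ring proves able to carry a clear change in maximal response: a number 23 percentage points higher from compound 2 to compound 3 (beyond the scatter), whereas the related (iodomethyl)carbonyl group stayed within the scatter of hydrogen. The halogen on the saturated chain carbon bound to a carbonyl carbon therefore matters in this series, with chloro in place of iodo giving a number 19 percentage points higher from compound 1 to compound 3 (beyond the scatter). Nothing available here explains why these two halogens differ.

Going by these compounds, it remains open what a (bromomethyl)carbonyl or (fluoromethyl)carbonyl group would give on the same nitrogen, and whether the chlorine is needed at all, which a plain acetyl group would test. On these data alone, it is equally open whether the response holds with a longer chain between the carbonyl and the chlorine.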